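A few compounds are considered here, and "the series" means these few. Any claim that something is new, unique, unknown or untested is made for them only; others in the source may bear on it.

Measured so far in a functional assay on MOLT-4 cells (Homo sapiens) for inhibition, read by sulforhodamine B assay, with a stated time of 48 h, tested at 1 uM; a lower number here means a stronger effect, a higher number a weaker effect of the compound at the concentration tested:
compound 1 `COc1cc(Cl)cc(-c2nn(-c3cccc(NC(=O)Nc4ccc(Cl)c(C(F)(F)F)c4)c3)cc2-c2ccncc2)c1` gives 58%
compound 2 `COc1cc(Cl)cc(-c2nn(-c3cccc(NC(=O)Nc4cc(C(F)(F)F)cc(C(F)(F)F)c4)c3)cc2-c2ccncc2)c1` gives 10%
compound 3 `COc1cc(Cl)cc(-c2nn(-c3cccc(NC(=O)Nc4ccc(Cl)c(Cl)c4)c3)cc2-c2ccncc2)c1` gives 70%

In this assay compound 3 stands highest of the three numbers, the weakest effect of the set; compound 1 is nearest, compound 2 far below. Compound 4 `COc1cc(Cl)cc(-c2nn(-c3cccc(NC(=O)Nc4cccc(C(F)(F)F)c4)c3)cc2-c2ccncc2)c1` differs from compound 3 in one place: 3-(trifluoromethyl)phenyl in place of 3,4-dichlorophenyl on an amide-type nitrogen. For the measured compounds named here, the only measured step touching this change is a number 12 percentage points higher from compound 1 to compound 3 (beyond the scatter), in which trifluoromethyl gave the lower number. Going by the values given here, in the present step trifluoromethyl returns to the ring, but the second chloro also leaves, and no measured pair covers that departure, so the direction rests on the one step alone. A modest fall is therefore expected, a number 15 percentage points lower from compound 3 to compound 4 (beyond the scatter). Compound 4 is estimated at 55%, expected between 35% and 75%.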

Compound 4, a percentage reported as activity, at one concentration (the size of the read-out at that concentration, not a potency): 55%
The estimate for compound 4 equals the measured number at the digits printed; low and high end bracket the measured number.
By their numbers in this assay, from the lowest: compound 2; then compounds 4 and 1 (each within the scatter of the next); then compound 3.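

In this assay, hydrogen in place of chloro on an aromatic carbon gives a number 3 percentage points lower from compound 1 to compound 4 (within the scatter), so this chloro does not separate the two compounds. The loss of one trifluoromethyl is a far larger step (a number 45 percentage points higher from compound 2 to compound 4 (beyond the scatter)), which makes the second trifluoromethyl of compound 2 the one substituent here with a large effect on the number. The change on the amide-type nitrogen is modest (a number 15 percentage points lower from compound 3 to compound 4 (beyond the scatter)), and compound 4 shows that a single trifluoromethyl does not reproduce the number of compound 2. From the compounds shown here alone, whether a nitrile or a carboxylic acid on this ring could stand in for that second trifluoromethyl remains open. Nothing available gives a reason for these differences.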